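The compounds below may be only part of what the source reports. "The series", "measured", "known", "first", "only" and "open" are said of these compounds alone.

In a functional assay on HCT-15 cells (Homo sapiens) for inhibition (a higher number here means a weaker inhibitor, a lower number a stronger inhibitor), compound 1 `Oc1cccc(-c2cc(-c3ccccc3F)cc(-c3cccc(O)c3)n2)c1` gives 5300 nM. Compound 2 `Oc1cccc(-c2cc(-c3cccc(F)c3)cc(-c3cccc(O)c3)n2)c1`, which carries 3-fluorophenyl in place of 2-fluorophenyl on an aromatic carbon, gives 7860 nM in this assay, so that a 1.5-fold higher number from compound 1 to compound 2 (0.17 log units; within the scatter). Compound 3 `Oc1ccc(-c2cc(-c3ccccc3F)cc(-c3ccc(O)cc3)n2)cc1` gives 8180 nM in this assay; this lies within the scatter of the numbers for compound 1 and compound 2, and the difference between its core and the core of compound 1 is not broken down here. Compound 4 `Oc1ccc(-c2cc(-c3cccc(F)c3)cc(-c3ccc(O)cc3)n2)cc1` has not yet been measured in this assay. It carries 3-fluorophenyl in place of 2-fluorophenyl on an aromatic carbon. For the measured compounds named here, this is the same kind of change as the one from compound 1 to compound 2, not the same: around the place, the two 3-hydroxyphenyl groups of compound 1 are replaced by two 4-hydroxyphenyl groups in compound 3. Because a 1.5-fold higher number from compound 1 to compound 2 (0.17 log units; within the scatter) stayed within the scatter, the step of a 1.3-fold higher number from compound 3 to compound 4 (0.11 log units; within the scatter) is expected to be of a similarly small size. Compound 4 is therefore estimated to give 10500 nM in this assay, with a range from 4500 nM to 24000 nM.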

Compound 4, half-maximal inhibitory concentration: > 50000 nM
Compound 4: no number, only a limit; the forecaster's own chance of this, stated with the estimate: 5%; at least 4.7-fold (0.67 log units) between middle value and limit.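

With the two 4-hydroxyphenyl groups in place, 3-fluorophenyl in place of 2-fluorophenyl gives an at least 6.1-fold higher number from compound 3 to compound 4 (0.78 log units; beyond the scatter), so in this assay the change does not carry over at the same size from the core of compound 1 to the core of compound 3: the same change on two cores in this assay, a 1.5-fold higher number (0.17 log units; within the scatter) from compound 1 to compound 2 and an at least 6.1-fold higher number (0.78 log units; beyond the scatter) from compound 3 to compound 4, at least 4.1-fold (0.61 log units) apart, beyond the scatter of two such steps. Compound 4 gives > 50000 nM, which is a limit of the assay and not a number: the limit of > 50000 nM in this assay, at which 1 of the 4 values shown sits. The two pairs show that the size of this step differs between these two cores, but they do not show how large the step on the core of compound 3 really is, what lies behind the difference, or whether it would hold on any other core.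

On these data alone, whether a core with one 3-hydroxyphenyl and one 4-hydroxyphenyl group would follow compound 1 or compound 3 stays open. So does the behaviour of the step with a chlorine atom in place of the fluorine, or with an amine in place of the hydroxyl groups.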